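The source may hold more compounds than are shown below. What is called first, only, known or untested is meant among the compounds shown, and "the series" means these compounds.

Measured so far:
- compound 1 `CC(C)(C)C#Cc1cc(N(C(=O)[C@H]2CC[C@H](C)CC2)[C@H]2CC[C@H](OC3COC3)CC2)c(C(=O)O)s1`: 8350 nM
- compound 2 `CC1=CC[C@H](C(=O)N(c2cc(C#CC(C)(C)C)sc2C(=O)O)[C@H]2CC[C@](O)(CO[C@H]3CCOC3)CC2)CC1`: 12100 nM

In an ADME assay on MT4 cells (Homo sapiens) for cytotoxicity, with a stated time of 5 days (a lower number here means that less compound is tolerated, a higher number that more compound is tolerated), compound 1 gives 8350 nM and compound 2 gives 12100 nM. The two numbers lie within the scatter of each other, so compound 1 does not stand apart from compound 2 on this evidence.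

The next compound is compound 3 `CC(C)(C)C#Cc1cc(N(C(=O)[C@H]2CC[C@H](C)CC2)[C@H]2CC[C@H](Oc3ccncn3)CC2)c(C(=O)O)s1`, which keeps the core of compound 1 and changes one group: pyrimidin-4-yl in place of oxetan-3-yl on an oxygen on a saturated carbon. A pyrimidin-4-yl ring, six-membered and aromatic, takes the place of the oxetan-3-yl ring on the oxygen.

Among the measured compounds shown here, no measured pair isolates a single change, so the size of this step has no direct precedent. Compound 2, at 12100 nM, differs from compound 1 in more than one place and still stays within the scatter of it, which argues against expecting a large move. A small shift towards a lower number is expected, possibly no larger than the scatter. The expected change is a 1.2-fold lower number from compound 1 to compound 3 (0.08 log units; within the scatter). For compound 3 the estimated value is 7000 nM, with an expected range of 3000 nM to 16000 nM.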

Compound 3, half-maximal cytotoxic concentration: 599 nM
The estimate for compound 3 lay 12-fold (1.07 log units) above the measured number, outside the stated range (below it).
By their numbers in this assay, from the lowest: compound 3; then compounds 1 and 2 (each within the scatter of the next).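

In this assay, pyrimidin-4-yl in place of oxetan-3-yl on an oxygen on a saturated carbon gives a 14-fold lower number from compound 1 to compound 3 (1.14 log units; beyond the scatter), and this is the only step shown that isolates a single change. With the rest of the core of compound 1 held constant, the group at this position can therefore shift the tolerated concentration well beyond the scatter. This one pair cannot separate the contributions of ring size, aromaticity and the two ring nitrogens, and no measurement on hand accounts for the step.

The compounds shown leave open whether phenyl, an aromatic six-membered ring without hetero atoms, on the same oxygen would fall near compound 3 at 599 nM or near compound 1 at 8350 nM. They also leave open whether a saturated six-membered ring such as tetrahydropyran-4-yl at this position would give a similar step, which would help to show whether the drop goes with the aromatic ring or with the larger ring.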